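The source may hold more compounds than are shown below. What is called first, only, known or untested is meant among the compounds shown, and "the series" means these compounds.

Working notes on the series. Compound 1 `CC(C)(C)Cc1c(Br)sc(N)c1C(=O)c1ccc(Cl)c(Cl)c1` and compound 2 `CC(C)(C)Cc1c(-c2ccccc2)sc(N)c1C(=O)c1ccccc1Cl` share a core; in an assay on CHO cells for displacement of a labelled ligand from adenosine receptor A3 (Homo sapiens), read by scintillation counting, tested at 10 uM (on this read-out higher numbers stand for more inhibition at the one concentration tested (going by the name of the read-out) and lower numbers for less inhibition), compound 1 gives 1% and compound 2 gives 1%, level with each other within the scatter. Compound 3 `CC(C)(C)Cc1c(-c2ccccc2)sc(N)c1C(=O)c1ccc(Cl)c(Cl)c1` differs from compound 2 by 3,4-dichlorophenyl in place of 2-chlorophenyl on a carbonyl carbon. Compound 1 already carries the 3,4-dichlorophenyl at the carbonyl, and its value sits level with compound 2, so no step beyond the scatter is expected from compound 2 to compound 3 in this assay, estimated as a number 1 percentage points higher from compound 2 to compound 3 (within the scatter). Compound 3 is therefore expected to give about 2%, within 0% to 12%.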

Compound 3, a percentage reported as inhibition, at one concentration (the size of the read-out at that concentration, not a potency): 6%
Beside the measured number, compound 3's estimate is 4 percentage points below it; measured number inside the range.
By their numbers in this assay, from the lowest: compounds 1, 2 and 3 (each within the scatter of the next).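

In this assay 3,4-dichlorophenyl in place of 2-chlorophenyl on a carbonyl carbon gives a number 5 percentage points higher from compound 2 to compound 3 (within the scatter) on a direct comparison at this place. Phenyl in place of bromo on an aromatic carbon gives a number 5 percentage points higher from compound 1 to compound 3 (within the scatter) in this assay and so also leaves the read-out within the scatter. No measurement at hand bears on the reason for these results. Still open, as far as these compounds go, is whether an amine or a carboxylic acid on that aromatic carbon would move the read-out beyond the scatter.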